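The source may report more compounds than this note shows. Statements on the series, on what has been measured and on what is new or still open speak of the compounds shown alone.

Measured so far:
compound 1 `O=C(Nc1cccc(C(F)(F)F)c1)Nc1nnc(Sc2ncnc3scc(-c4ccncc4)c23)s1` – 11500 nM
compound 2 `COc1ccc(NC(=O)Nc2nnc(Sc3ncnc4scc(-c5ccncc5)c34)s2)cc1` – 9900 nM

Among the measured compounds shown here, in a functional assay on PC-3 cells (Homo sapiens) for antiproliferative activity, read by MTT assay, with a stated time of 48 h (on this read-out higher numbers stand for weaker inhibition and lower numbers for stronger inhibition), compound 2 holds the lowest of the two numbers, and its nearest neighbour is compound 1; the only measured step, a 1.2-fold lower number from compound 1 to compound 2 (0.07 log units; within the scatter), lies within the scatter. Compound 3 `O=C(Nc1ccc(Cl)cc1)Nc1nnc(Sc2ncnc3scc(-c4ccncc4)c23)s1` differs from compound 2 by chloro in place of methoxy on an aromatic carbon. For the measured compounds named here, no measured step swaps methoxy for chloro, so the one step known, a change of the group on the same nitrogen that hardly moved the number, is the sole guide. Compound 3 is therefore expected to show no step beyond the scatter, a 1.0-fold higher number from compound 2 to compound 3 (0.00 log units; within the scatter), with an estimate of 10000 nM in a range from 5000 nM to 20000 nM.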

Compound 3, half-maximal inhibitory concentration: 7700 nM
Compound 3: the middle estimate sits 1.3-fold (0.11 log units) above what was measured; the range from low to high includes it.
By their numbers in this assay, from the lowest: compounds 3, 2 and 1 (each within the scatter of the next).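

In this assay, chloro in place of methoxy, para to a large group, gives a 1.3-fold lower number from compound 2 to compound 3 (0.11 log units; within the scatter) and so adds a second kind of substituent at this ring carbon with no shift beyond the scatter. Exchanging the whole group, 4-chlorophenyl for 3-(trifluoromethyl)phenyl, gives a 1.5-fold lower number from compound 1 to compound 3 (0.17 log units; within the scatter) and likewise stays within it, so all three compounds read alike. Nothing measured here offers an explanation for these numbers. As far as these compounds go, whether an amine or a carboxylic acid on this ring carbon would move the number beyond the scatter stays open, as does the effect of any change to the shared core.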